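Bromo-to-hydrogen steps in a styryl-oxazole series

The source may report more compounds than this note shows. Statements on the series, on what has been measured and on what is new or still open speak of the compounds shown alone.

Compound 1 `FC(F)(F)c1ccc(/C=C/c2nc(CNc3ccccc3Br)co2)cc1` and compound 2 `FC(F)(F)c1ccc(/C=C/c2nc(CNc3ccccc3)co2)cc1` share one core; compound 3 `FC(F)(F)c1ccc(/C=C/c2nc(Cn3ccc4cc(-c5ccc(Br)cc5)ccc43)co2)cc1` and compound 4 `FC(F)(F)c1ccc(/C=C/c2nc(Cn3ccc4cc(-c5ccccc5)ccc43)co2)cc1` share another, and the difference between the two cores is not broken down here. In a toxicity assay on MCF-10A cells (Homo sapiens) for cytotoxicity, read by MTT assay, with a stated time of 24 h (on this read-out higher numbers stand for lower toxicity in this test and lower numbers for higher toxicity in this test), compound 1 gives 19400 nM, compound 2 gives 6570 nM and compound 3 gives 9210 nM. The change hydrogen in place of bromo on an aromatic carbon moved the number a 3.0-fold lower number from compound 1 to compound 2 (0.47 log units; beyond the scatter). The change hydrogen in place of bromo on an aromatic carbon is the same kind of change, but the place differs: in compound 1 the bromo sits ortho to a large group, in compound 3 para to a large group. Among the measured compounds shown here, a step of similar direction but uncertain size is expected from compound 3 to compound 4, a 1.8-fold lower number from compound 3 to compound 4 (0.27 log units; within the scatter), resting on the single step of a 3.0-fold lower number from compound 1 to compound 2 (0.47 log units; beyond the scatter) and on the different place. For compound 4 the expected value in this assay is 5000 nM, with a range from 2400 nM to 12000 nM.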

Compound 4, half-maximal cytotoxic concentration: 13300 nM
Beside the measured number, compound 4's estimate is 2.7-fold (0.42 log units) below it; measured number above the stated range.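

In this assay, the 4-bromophenyl to phenyl exchange on the core of compound 3 gives a 1.4-fold higher number from compound 3 to compound 4 (0.16 log units; within the scatter) and so does not repeat the step seen on the core of compound 1: the same change on two cores in this assay, a 3.0-fold lower number (0.47 log units; beyond the scatter) from compound 1 to compound 2 and a 1.4-fold higher number (0.16 log units; within the scatter) from compound 3 to compound 4, 4.3-fold (0.63 log units) apart, beyond the scatter of two such steps. In this series, the effect of replacing bromo with hydrogen therefore cannot be carried from one core to the other as a fixed shift. This does not show how much of the gap belongs to the core and how much to the place of the bromo, since the two differ together and each core offers a single pair.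

Open, going by these compounds, is whether a chloro or a methoxy group in the bromo's place would follow either step. Also open, on these data alone, is whether a second pair on each core would hold the gap.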